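Chain truncation at the aromatic carbon of the shared core

The source may hold more compounds than are shown below. What is called first, only, known or untested is meant among the compounds shown, and "the series" means these compounds.

Measured compounds in an assay on HEK293 cells for agonist activity at Toll-like receptor 8 (Homo sapiens), read by spectrophotometry; on this read-out lower numbers stand for an effect already at smaller amounts and higher numbers for an effect only at larger amounts of compound:
compound 1 `CCCCNc1nc(N)nc(C)c1CCCC`: 780 nM
compound 2 `CCCCNc1nc(N)nc(C)c1CCCn1cncn1`: 1050 nM
compound 3 `CCCCNc1nc(N)nc(C)c1CCCn1cccn1`: 1050 nM

Compound 3 stands level with compound 2 at the digits shown, the two together giving the highest numbers of the three; its only other neighbour is compound 1, and the gap from compound 1 to compound 3 is a 1.3-fold higher number from compound 1 to compound 3 (0.13 log units; within the scatter). All three measured compounds share the same core and differ only in what sits on the saturated chain carbon three bonds along the chain from an aromatic carbon: a 1.3-fold higher number from compound 1 to compound 2 (0.13 log units; within the scatter) and no change at the digits printed from compound 2 to compound 3 (within the scatter), both within the scatter.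

Compound 4 `CCCCNc1nc(N)nc(C)c1C` arises from compound 3 by hydrogen in place of 2-(1H-pyrazol-1-yl)ethyl on a saturated chain carbon bound to an aromatic carbon. For the measured compounds named here, none of the measured steps touches this place; all three change the end of the chain and leave its length untouched, so they say nothing direct about shortening it. Going by the values given here, the expectation therefore rests on no measured step and is correspondingly uncertain. Without any comparable change in the series, the working estimate for compound 4 in this assay is 3000 nM with a range from 600 nM to 15000 nM, which is expected to mean a step of a 2.9-fold higher number from compound 3 to compound 4 (0.46 log units; beyond the scatter) relative to compound 3, and the range is set wide on purpose.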

Compound 4, half-maximal effective concentration: 3280 nM
The estimate for compound 4 lay 1.1-fold (0.04 log units) below the measured number, and the stated range covers the measured number.
By their numbers in this assay, from the lowest: compounds 1, 2 and 3 (each within the scatter of the next); then compound 4.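

Within this assay, this is the first change at this place to go beyond the scatter: hydrogen in place of 2-(1H-pyrazol-1-yl)ethyl gives a 3.1-fold higher number from compound 3 to compound 4 (0.49 log units; beyond the scatter), and hydrogen in place of 2-(1H-1,2,4-triazol-1-yl)ethyl gives a 3.1-fold higher number from compound 2 to compound 4 (0.49 log units; beyond the scatter). Hydrogen in place of propyl gives a 4.2-fold higher number from compound 1 to compound 4 (0.62 log units; beyond the scatter), so among these compounds, removing the chain moves the number beyond the scatter, whereas exchanging its end for either ring did not. Nothing available on these compounds accounts for the rise in the number.

Going by these compounds, it remains open how the number runs for chains of intermediate length or for a longer chain. On these data alone, it is also open whether an amine or a carboxylic acid at the chain end would stay level with the ring-bearing chains.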